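The compounds below may be only part of what the source reports. "The series", "measured", "known", "first", "only" and "open" are said of these compounds alone.

Measured compounds:
compound 1 `NC(=O)c1cccc(Cn2cc(-c3ccc4cn[nH]c4c3)ccc2=O)c1` — 106 nM
compound 2 `O=c1ccc(-c2ccc3cc[nH]c3c2)cn1Cc1ccccc1` — > 2000 nM
compound 3 `Nc1n[nH]c2cc(-c3ccc(=O)n(Cc4ccccc4)c3)ccc12` — 32 nM

In an assay for inhibition of MAP kinase-interacting serine/threonine-protein kinase 2 (Homo sapiens), read by luminescence and ADP-Glo, with a stated time of 2 h (a higher number here means a weaker inhibitor, a lower number a stronger inhibitor), compound 1 gives 106 nM. Compound 3 gives 32 nM, a lower number beyond the scatter, so compound 1 has the highest of the two numbered values. For compound 2 this assay reports only a limit, > 2000 nM (the limit of > 2000 nM in this assay, at which 1 of the 3 values shown sits).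

Compound 4 `O=c1ccc(-c2ccc3cn[nH]c3c2)cn1Cc1cccc(F)c1` awaits measurement in this assay. It differs from compound 1 as fluoro in place of carbamoyl on an aromatic carbon. For the measured compounds named here, no measured pair differs in just this way, so the step has no direct precedent. A modest weakening beyond the scatter is expected. Compound 4 is estimated at 250 nM, with a range of 80 nM to 800 nM. For compound 4 this expected step is a 2.4-fold higher number from compound 1 to compound 4 (0.37 log units; beyond the scatter).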

Compound 4, half-maximal inhibitory concentration: 38 nM
Beside the measured number, compound 4's estimate is 6.6-fold (0.82 log units) above it; the whole stated range lies above it.
By their numbers in this assay, from the lowest: compounds 3 and 4 (each within the scatter of the next); then compound 1. At a limit, above all of these: compound 2.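

In this assay the change to fluoro in place of carbamoyl gives a 2.8-fold lower number from compound 1 to compound 4 (0.45 log units; beyond the scatter) on this aromatic carbon, meta to a large group. The carbamoyl, with its hydrogen-bond donor and acceptor, is therefore not required here for inhibition at this level, and a single fluorine atom serves at least as well. No measurement shown bears on the cause of this step. The compounds shown leave open whether fluoro itself or the loss of carbamoyl accounts for the step, and how a chloro, methoxy or nitrile group would read at this carbon.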